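Trifluoromethoxy for bromo on the aniline ring

The source may report more compounds than this note shows. Statements on the series, on what has been measured and on what is new or still open speak of the compounds shown alone.

Measured so far:
- compound 1 `Cc1cccc(Nc2cc(C3CC3)c(C(=O)NCC3CCOCC3)cn2)c1`: "not determined" (no result reported)
- compound 2 `O=C(NCC1CCOCC1)c1cnc(Nc2cccc(F)c2)cc1C1CC1`: "not determined" (no result reported)
- compound 3 `O=C(NCC1CCOCC1)c1cnc(Nc2cccc(Br)c2)cc1C1CC1`: 83400000 ng.h/mL

Three compounds of the series have been run in an ADME assay on the whole organism for pharmacokinetics, with Rattus norvegicus as the target, with a stated time of 6 h, at a dose of 30 mg/kg by the oral route; on this read-out higher numbers stand for higher exposure at the dose given and lower numbers for lower exposure. Compound 1 gives "not determined" (no result reported) in this assay, and compound 2 likewise gives "not determined" (no result reported), so neither yields a number to compare against. Among the measured compounds shown here, compound 3 is the only one with a result, 83400000 ng.h/mL, and it therefore stands alone; no ordering can be drawn from a single number, and no step between measured compounds can be stated.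

The next compound is compound 4 `O=C(NCC1CCOCC1)c1cnc(Nc2cccc(OC(F)(F)F)c2)cc1C1CC1`. It differs from compound 3 in one place: trifluoromethoxy in place of bromo on an aromatic carbon. The shared core and the amide side chain are unchanged.

For the measured compounds named here, with no measured step in this assay to lean on, the expectation for compound 4 rests on the single number of compound 3 and the size of the change. The step from compound 3 to compound 4 is expected to be a 1.4-fold lower number from compound 3 to compound 4 (0.14 log units; within the scatter), that is, no change beyond the usual scatter, perhaps leaning slightly downward. Compound 4 is therefore estimated at 60000000 ng.h/mL in this assay, with a range from 20000000 ng.h/mL to 170000000 ng.h/mL.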

Compound 4, area under the concentration-time curve: 50000000 ng.h/mL
Estimate against measurement, compound 4: 1.2-fold (0.08 log units) above; low and high end bracket the measured number.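

In this assay, among the compounds shown here, the exchange of bromo for trifluoromethoxy on the aniline ring provides the only readable step at this position so far: a 1.7-fold lower number from compound 3 to compound 4 (0.22 log units; within the scatter). This step lies within the scatter, so the data separate neither compound from the other on exposure. At this position, a substituent of five heavy atoms with one hydrogen-bond acceptor has therefore taken the place of a single bromine without a difference that can be distinguished in this read-out. No supporting measurement bears on why the two compounds read alike.

Steps involving compound 1 and compound 2 cannot be read, so the methyl and fluoro members of the series add nothing yet to the picture at this position. Still open, as far as these compounds go, is whether an amine or a carboxylic acid on the same aromatic carbon, or a longer chain in place of the amide side chain, would shift exposure beyond the scatter, since a single step within the scatter sets no trend for either site.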